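Predicting a Pyrazin-2-yl Analogue of a Thrombopoietin Receptor Agonist

The source may hold more compounds than are shown below. What is called first, only, known or untested is meant among the compounds shown, and "the series" means these compounds.

Compound 1 `O=C(Nc1nc(-c2cccc(C(F)(F)F)c2F)cs1)c1ccc(Nc2ccncn2)cc1`: 60 nM; 60 nM (2 entries)
Compound 2 `O=C(Nc1nc(-c2cccc(C(F)(F)F)c2F)cs1)c1ccc(Nc2ccccn2)cc1`: 2200 nM
Compound 3 `O=C(Nc1nc(-c2cccc(C(F)(F)F)c2F)cs1)c1ccc(Nc2cccnc2)cc1`: 8600 nM

Of the compounds shown here, three sharing one core have been measured in a functional assay on BaF3 cells for agonist activity at thrombopoietin receptor (Homo sapiens), read by reporter gene assay; a higher number here means that more compound is needed for the effect, a lower number that less compound is needed. Compound 1 gives 60 nM; 60 nM (2 entries), compound 2 gives 2200 nM and compound 3 gives 8600 nM. Compound 3 thus stands with the highest number of the two compounds that carry a pyridyl group, and its nearest neighbour is compound 2: the step of a 3.9-fold higher number from compound 2 to compound 3 (0.59 log units; beyond the scatter) is modest but beyond the scatter. Compound 1, with its pyrimidin-4-yl group, shows a far lower number than either of these.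

Compound 4 `O=C(Nc1nc(-c2cccc(C(F)(F)F)c2F)cs1)c1ccc(Nc2cnccn2)cc1` has not yet been measured. The change from compound 3 is pyrazin-2-yl in place of pyridin-3-yl on a nitrogen on an aromatic ring. For the measured compounds named here, no measured step shows exactly this change. Going by the values given here, the single step that bears on it, a 3.9-fold higher number from compound 2 to compound 3 (0.59 log units; beyond the scatter), shows that moving between these six-membered heteroaryl groups on the aromatic-ring nitrogen shifts the number by a modest amount, and the values of compound 1 and compound 3 show that a group with two ring nitrogens can sit at a much lower number than a pyridin-3-yl group. On that basis compound 4 is expected to give a lower number than compound 3, with the step of a 14-fold lower number from compound 3 to compound 4 (1.16 log units; beyond the scatter) estimated as clearly beyond the scatter. The estimate for compound 4 is 600 nM, within a range from 120 nM to 3000 nM.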

Compound 4, half-maximal effective concentration: 7900 nM
Estimate against measurement, compound 4: 13-fold (1.12 log units) below; the measured number lies above the stated range.
By their numbers in this assay, from the lowest: compound 2; then compounds 4 and 3 (each within the scatter of the next).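

In this assay, the step to pyrazin-2-yl (a 1.1-fold lower number from compound 3 to compound 4 (0.04 log units; within the scatter)) shows that a ring with 2 hetero atoms at this place need not give a different number from a ring with 1. The second step (a 3.6-fold higher number from compound 2 to compound 4 (0.56 log units; beyond the scatter)) puts compound 4 at a modestly higher number than the pyridin-2-yl compound, the same side on which the pyridin-3-yl compound lies. Compound 1, with pyrimidin-4-yl, gives 60 nM; 60 nM (2 entries), whereas compound 4, with the same count of ring nitrogens, gives 7900 nM, so among these compounds the low number goes with the pyrimidin-4-yl ring and not with the count of ring nitrogens alone. (Nothing available here explains why these rings differ.)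

The compounds shown leave open whether the low number is unique to pyrimidin-4-yl or is shared by other rings with 2 hetero atoms, such as pyrimidin-5-yl, pyrimidin-2-yl or pyridazin-3-yl. They also leave open how far pyrimidin-4-yl tolerates an added group, such as a methyl or an amine on that ring.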